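Chloro to hydrogen on the pendant ring of compound 1

The source may hold more compounds than are shown below. What is called first, only, known or untested is meant among the compounds shown, and "the series" means these compounds.

Measured compounds:
- compound 1 `COc1cc(-c2ccnc3cc(-c4ccc(Cl)cc4)nn23)cc(OC)c1OC`: 4090 nM
- compound 2 `COc1cc(-c2cc3nccc(-c4c[nH]c5ccccc45)n3n2)cc(OC)c1OC`: > 10000 nM
- compound 3 `Cc1ccc(-c2cc3nccc(-c4ccc(F)cc4)n3n2)cc1`: > 10000 nM

Within the data shown here, in a functional assay on B16-F0 cells (Mus musculus) for inhibition, read by CCK-8 assay, with a stated time of 48 h (a higher number here means a weaker inhibitor, a lower number a stronger inhibitor), compound 1 gives 4090 nM, the only number among the three values shown. For compound 2 the value > 10000 nM is a limit of the assay and not a number. For compound 3 the value > 10000 nM is likewise a limit. Two of three values thus sit at the limit of > 10000 nM in this assay, at which 2 of the 3 values shown sit.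

Compound 4 `COc1cc(-c2ccnc3cc(-c4ccccc4)nn23)cc(OC)c1OC` is not yet measured in this assay. It differs from compound 1 by hydrogen in place of chloro on an aromatic carbon, that is, 4-chlorophenyl becomes phenyl. With no measured step of this kind in the set, a modest loss is expected, so the step from compound 1 to compound 4 is estimated at a 1.6-fold higher number from compound 1 to compound 4 (0.20 log units; within the scatter). Compound 4 is expected to give about 6500 nM, within 2500 nM to 16000 nM.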

Compound 4, half-maximal inhibitory concentration: 4730 nM
Compound 4: middle estimate off by 1.4-fold (0.14 log units), on the high side; the range from low to high includes it.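

In this assay, among these compounds, the change of 4-chlorophenyl to phenyl gives a 1.2-fold higher number from compound 1 to compound 4 (0.06 log units; within the scatter) as the first measured step at this position. Chloro on this ring is therefore not needed for compound 4 to keep a measurable value in the range of compound 1. No available measurement gives a reason for this step in terms of a property of either group.

From the compounds shown here alone, whether an amine or a carboxylic acid in place of chloro on this aromatic carbon would keep such a value stays open. The compounds shown also leave open whether any group here can give a step beyond the scatter.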